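The compounds below may be only part of what the source reports. "The series", "measured", "known", "first", "only" and "open" are said of these compounds alone.

In a functional assay on HepG2 cells (Homo sapiens) for inhibition, read by MTT assay (a higher number here means a weaker inhibitor, a lower number a stronger inhibitor), compound 1 `COc1cc2ncnc(Nc3ccc(NC(=O)c4cccc(C)c4)cc3)c2cc1OC` gives 7500 nM and compound 3 `COc1cc2ncnc(Nc3ccc(NC(=O)c4cccc(F)c4)cc3)c2cc1OC` gives 8200 nM while compound 2 `CCc1ccc(C(=O)Nc2ccc(Nc3ncnc4cc(OC)c(OC)cc34)cc2)cc1` gives 72000 nM in the same test. Compound 3 therefore holds the middle of the three numbers, though the gap is only a 1.1-fold higher number from compound 1 to compound 3 (0.04 log units; within the scatter). Compound 2 stands apart, with an 8.8-fold lower number from compound 2 to compound 3 (0.94 log units; beyond the scatter) on the way back down.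

Compound 4 `COc1cc2ncnc(Nc3ccc(NC(=O)c4ccccc4Cl)cc3)c2cc1OC` keeps the shared core and places 2-chlorophenyl in place of 3-fluorophenyl on a carbonyl carbon as its only difference. Among the measured compounds shown here, no measured compound carries this group, so the evidence is indirect. The exchange of methyl for fluoro in compound 3 gave a 1.1-fold higher number from compound 1 to compound 3 (0.04 log units; within the scatter) and suggests tolerance, while compound 2 shows with a 9.6-fold higher number from compound 1 to compound 2 (0.98 log units; beyond the scatter) that some changes on this ring cost more. A small rise at most seems likely, with a larger one not excluded. The expected result is a 1.2-fold higher number from compound 3 to compound 4 (0.09 log units; within the scatter) for this single change. For compound 4 the estimated value is 10000 nM with an expected range from 4000 nM to 35000 nM in this test.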

Compound 4, half-maximal inhibitory concentration: 26000 nM
Compound 4: the middle estimate sits 2.6-fold (0.41 log units) below what was measured; measured number inside the range.
By their numbers in this assay, from the lowest: compounds 1 and 3 (each within the scatter of the next); then compound 4; then compound 2.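

In this assay, 2-chlorophenyl on the carbonyl carbon gives a 3.2-fold higher number from compound 3 to compound 4 (0.50 log units; beyond the scatter) and a 3.5-fold higher number from compound 1 to compound 4 (0.54 log units; beyond the scatter), so the tolerance seen in the swap from 3-methylphenyl to 3-fluorophenyl does not extend to every substituted phenyl at this place. Compound 4 still does not reach the level of compound 2, with a 2.8-fold lower number from compound 2 to compound 4 (0.44 log units; beyond the scatter), so the position now shows an intermediate level and not just two separate ones. Nothing in the data available here explains this shift.

Chlorine and its place on the ring change together from compound 3 to compound 4, so the compounds shown leave open which of the two goes with the rise. On these data alone, how an amine or a carboxylic acid on this ring would read also stays open.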